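The source may hold more compounds than are shown below. What is called first, only, known or untested is meant among the compounds shown, and "the series" means these compounds.

Measured so far in an assay (Rattus norvegicus) for inhibition of Fatty-acid amide hydrolase 1 (Homo sapiens); on this read-out higher numbers stand for weaker inhibition and lower numbers for stronger inhibition:

compound 1, `COc1ccccc1-c1cnc(C(=O)CCCCCCc2ccccc2)o1`, 400 nM
compound 2, `Nc1cccc(-c2cnc(C(=O)CCCCCCc3ccccc3)o2)c1`, 19 nM
compound 3, `N#Cc1ccc(-c2cnc(C(=O)CCCCCCc3ccccc3)o2)cc1`, 40 nM

Compound 3 stands second highest of the three numbers in this assay. Its nearest neighbour is compound 2, with a 2.1-fold higher number from compound 2 to compound 3 (0.32 log units; beyond the scatter); its furthest is compound 1, with a 10-fold lower number from compound 1 to compound 3 (1.00 log units; beyond the scatter). The three compounds share one core and differ only in the aromatic group attached to it, so all three steps bear on a change at that position. The largest is a 21-fold lower number from compound 1 to compound 2 (1.32 log units; beyond the scatter), the smallest a 2.1-fold higher number from compound 2 to compound 3 (0.32 log units; beyond the scatter); the aromatic group at this place therefore moves the number appreciably across the compounds seen.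

Compound 4, `Cc1cccc(-c2cnc(C(=O)CCCCCCc3ccccc3)o2)n1`, has not yet been measured. It differs from compound 3 in one place: 6-methylpyridin-2-yl in place of 4-cyanophenyl on an aromatic carbon. The entering group keeps one hydrogen-bond acceptor and no donor, as the leaving group does, and loses the triple bond outside the ring. Among the compounds with values here, no measured step pairs a pyridine-containing group against a carbon-only ring, so the direction rests on the general spread seen between compound 1, compound 2 and compound 3 rather than on a matching precedent.

For compound 4 the expected step is a 1.3-fold lower number from compound 3 to compound 4 (0.12 log units; within the scatter), a change within or close to the scatter. Compound 4 is estimated at 30 nM in this assay, with a range from 8 nM to 120 nM.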

Compound 4, inhibition constant: 3.3 nM
Compound 4: middle estimate off by 9.1-fold (0.96 log units), on the high side; measured number below the stated range.
By their numbers in this assay, from the lowest: compound 4; then compound 2; then compound 3; then compound 1.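

In this assay, 6-methylpyridin-2-yl on the aromatic carbon next to the ring oxygen gives a 12-fold lower number from compound 3 to compound 4 (1.08 log units; beyond the scatter), along with a 5.8-fold lower number from compound 2 to compound 4 (0.76 log units; beyond the scatter) and a 120-fold lower number from compound 1 to compound 4 (2.08 log units; beyond the scatter), so compound 4 has the lowest number of the four and its steps to all the others lie beyond the scatter. Compound 4 is the only one shown with a hetero atom in this six-membered aromatic ring, and this position therefore tolerates such a ring and can reach a lower number with it than with any of the carbon-only rings of compound 1, compound 2 and compound 3. Compound 3 and compound 4 have the same counts of hydrogen-bond donors and acceptors in the changed group, so those counts do not separate the two numbers, and nothing at hand explains the step.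

Going by these compounds, the change swaps the ring and adds a methyl at once, so the share of each remains open; a plain pyridin-2-yl group and a 3-methylphenyl group would separate them. Also open, on these data alone, is whether the step holds with a shorter chain between the carbonyl and the terminal phenyl.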